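Adding a second chloro to compound 2

A few compounds are considered here, and "the series" means these few. Any claim that something is new, unique, unknown or untested is made for them only; others in the source may bear on it.

compound 1 `CN(C)c1ccc2cc(-c3ccccc3)c(N)nc2c1`: < 0.1 h (a limit of the assay)
compound 2 `CN(C)c1ccc2cc(-c3ccccc3Cl)c(N)nc2c1`: 0.13 h
compound 3 `CN(C)c1ccc2cc(-c3ccc(Cl)cc3)c(N)nc2c1`: 0.18 h

In an ADME assay on microsomes from liver (Mus musculus) for metabolic stability, read by HPLC, with a stated time of 4 h (a higher number here means that the compound lasts longer, a lower number that the compound disappears faster), compound 2 gives 0.13 h. Compound 3 gives 0.18 h, so compound 2 stands within the scatter of its nearest neighbour: a 1.4-fold higher number from compound 2 to compound 3 (0.14 log units; within the scatter). Compound 4 `CN(C)c1ccc2cc(-c3cccc(Cl)c3Cl)c(N)nc2c1` carries one further change from compound 2: chloro in place of hydrogen on an aromatic carbon, a chloro in place of hydrogen on an aromatic carbon. Two measured steps make the same kind of swap, an at least 1.3-fold higher number from compound 1 to compound 2 (0.11 log units; that floor lies within the scatter) and an at least 1.8-fold higher number from compound 1 to compound 3 (0.25 log units; that floor lies within the scatter), and with these floors no step beyond the scatter is expected in this assay. As far as these compounds go, both floors start from the limit of compound 1, so their true sizes remain unknown. The expected step is a 1.2-fold higher number from compound 2 to compound 4 (0.09 log units; within the scatter). For compound 4 the estimated half-life is 0.16 h, with an expected range from 0.1 h to 0.3 h.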

Compound 4, half-life: 0.15 h
Estimate against measurement, compound 4: 1.1-fold (0.03 log units) above; low and high end bracket the measured number.
By their numbers in this assay, from the lowest: compounds 2, 4 and 3 (each within the scatter of the next). At a limit, below all of these: compound 1.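

In this assay, a second chloro, ortho to a chloro group and meta to a large group, gives a 1.2-fold higher number from compound 2 to compound 4 (0.06 log units; within the scatter), so the half-life shows no step beyond the scatter at this position. This is also the first reading of this change that starts from a real number rather than a limit, and it can be set beside the earlier one: the same change on two cores in this assay, an at least 1.8-fold higher number (0.25 log units; that floor lies within the scatter) from compound 1 to compound 3 and a 1.2-fold higher number (0.06 log units; within the scatter) from compound 2 to compound 4; the limit leaves it open whether they differ

The compounds shown leave open whether a different group at this position, such as an amine or a carboxylic acid, would shift the half-life beyond the scatter.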